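The source may hold more compounds than are shown below. What is called first, only, known or untested is meant among the compounds shown, and "the series" means these compounds.

Measured so far:
- compound 1, `CCCCc1cc2c(=O)c(CC)c[nH]c2cc1OCCOc1ccccc1` — 360 nM
- compound 2, `CCCCc1ccc2[nH]cc(C(=O)OC)c(=O)c2c1` — > 20000 nM
- compound 3, `CCc1cc2c(=O)c(C(=O)OC)c[nH]c2cc1OCCOc1ccccc1` — > 20000 nM

Of the compounds shown here, three sharing one core have been tested in an ADME assay on J774 cells (Mus musculus) for cytotoxicity; on this read-out lower numbers stand for an effect already at smaller amounts and higher numbers for an effect only at larger amounts of compound. Compound 1 gives 360 nM and is the only one of the three with a number rather than a limit. For compound 2 the result is a limit of the assay, > 20000 nM, and not a number. For compound 3 the result is likewise a limit of the assay, > 20000 nM. Both compounds that carry a methyl ester on the core thus sit at the limit of > 20000 nM in this assay, at which 2 of the 3 values shown sit, while compound 1, with an ethyl group in that position, shows its effect at a far smaller amount.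

Compound 4, `CCCCc1cc2c(=O)c(C(=O)NCCO)c[nH]c2cc1OCCOc1ccccc1`, has not been measured. It comes from compound 1 by (2-hydroxyethyl)carbamoyl in place of ethyl on an aromatic carbon. Among the measured compounds shown here, no step between measured compounds has been recorded for this kind of change, so the expectation rests on what compounds 2 and 3 show for another carbonyl-bearing group in the same place. A step toward a larger amount is expected, beyond the scatter: the estimated change a 22-fold higher number from compound 1 to compound 4 (1.35 log units; beyond the scatter) means that compound 4 is expected to land around 8000 nM, within 1500 nM to 20000 nM, with a real chance that only a limit is reported.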

Compound 4, half-maximal effective concentration: > 20000 nM
Compound 4 ended at the assay's limit (the forecaster's own chance of this, stated with the estimate: 45%); middle value at least 2.5-fold (0.39 log units) from the limit.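

Compounds 2 and 3 each differ from compound 1 in more than one place, whereas compound 4 changes only the group on this aromatic carbon, two atoms from the ring nitrogen. In this assay, (2-hydroxyethyl)carbamoyl in place of ethyl gives an at least 55-fold higher number from compound 1 to compound 4 (1.74 log units; beyond the scatter), a large step from one change with the rest of the molecule left as it was. Compound 4 gives > 20000 nM, a limit of the assay and not a number, so the step marks only a minimum size, and this compound joins the others at that limit: the limit of > 20000 nM in this assay, at which 3 of the 4 values shown sit.

The compounds shown do not separate the parts of the entering group, so the carbonyl, the amide hydrogen and the hydroxyl at the end of the chain cannot be told apart in their share of the step. As far as these compounds go, how a plain primary amide, a carboxylic acid, an amine or a longer alkyl chain on this carbon would read in this assay stays open, as does whether a step of this size would appear with other groups elsewhere on the shared core.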